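A few compounds are considered here, and "the series" means these few. Any claim that something is new, unique, unknown or untested is made for them only; others in the source may bear on it.

Measured in a functional assay on DLD-1 cells (Homo sapiens) for cytotoxicity, with a stated time of 48 h; a lower number here means a stronger inhibitor, a higher number a weaker inhibitor:
compound 1 `CC(=O)Oc1ccc2oc(/C=C/[S+](C)[O-])cc(=O)c2c1`: > 10000 nM
compound 2 `C[S+]([O-])/C=C/c1cc(=O)c2ccccc2o1`: 8000 nM

Compound 1 sits at the limit of > 10000 nM in this assay, at which 1 of the 2 values shown sits, which is a limit and not a number. For the measured compounds named here, compound 2, at 8000 nM, therefore holds the only actual number so far. Compound 3 `Cc1cccc2c(=O)cc(/C=C/[S+](C)[O-])oc12` differs from compound 2 by a single change, methyl in place of hydrogen on an aromatic carbon. Going by the values given here, the one measured step, an at least 1.2-fold lower number from compound 1 to compound 2 (0.09 log units; that floor lies within the scatter), involves a different change, hydrogen in place of acetoxy, and its floor lies within the scatter, so it offers no size to carry over. No step beyond the scatter is expected in this assay, and no direction can be favoured. A reading that is again only a limit is quite possible. For compound 3 the estimated value is 8000 nM, expected to fall between 4000 nM and 16000 nM. The expected step is no change at the digits printed from compound 2 to compound 3 (within the scatter).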

Compound 3, half-maximal inhibitory concentration: 6800 nM
Estimate against measurement, compound 3: 1.2-fold (0.07 log units) above; the measured number falls inside the stated range.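

In this assay, methyl in place of hydrogen on an aromatic carbon, ortho to a fused ring and meta to a fused ring, gives a 1.2-fold lower number from compound 2 to compound 3 (0.07 log units; within the scatter). The earlier step rested on a limit, whereas this one joins two actual numbers, so the change has a readable size, and that size does not separate the two compounds. Compound 1 remains the only one of the three at a limit, which is not a number: the limit of > 10000 nM in this assay, at which 1 of the 3 values shown sits.

The compounds shown leave open whether an amine or a carboxylic acid on this same aromatic carbon would give a step beyond the scatter. They also leave open whether methyl on another aromatic carbon of the shared core would read the same way.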